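Swapping the Aryl Group on the Shared Core of Compound 2

The source may hold more compounds than are shown below. What is called first, only, known or untested is meant among the compounds shown, and "the series" means these compounds.

Measured so far in a functional assay on MCF7 cells (Homo sapiens) for inhibition, read by CCK-8 assay; a lower number here means a stronger inhibitor, a higher number a weaker inhibitor:
- compound 1, `Oc1ccccc1/C=N/c1nnc(SCc2nnc(-c3ccccc3)o2)s1`: 9760 nM
- compound 2, `Cc1ccccc1-c1nnc(CSc2nnc(/N=C/c3ccccc3O)s2)o1`: 9360 nM

Both measured compounds share one core and differ only in a single group on an aromatic carbon. The step of a 1.0-fold lower number from compound 1 to compound 2 (0.02 log units; within the scatter) shows that adding a methyl there made no difference that could be told from repeat measurements. Compound 2 therefore stands at the lowest of the two numbers in this assay, but its gap to compound 1 is within the scatter, so the two count as equal.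

Compound 3, `O=[N+]([O-])c1ccc(-c2nnc(CSc3nnc(/N=C/c4ccccc4O)s3)o2)cc1`, changes compound 2 in one place: 4-nitrophenyl in place of 2-methylphenyl on an aromatic carbon. Among the measured compounds shown here, no measured step bears directly on this change; the only step known, a 1.0-fold lower number from compound 1 to compound 2 (0.02 log units; within the scatter), concerns a much smaller group on the same ring and was flat. Nothing in the two numbers available argues for a sizeable move in either direction, so the expectation is a step about the size of the scatter, a 1.2-fold lower number from compound 2 to compound 3 (0.07 log units; within the scatter). Compound 3 is therefore expected to give about 8000 nM in this assay, with a range from 2500 nM to 25000 nM.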

Compound 3, half-maximal inhibitory concentration: 4250 nM
Estimate against measurement, compound 3: 1.9-fold (0.27 log units) above; low and high end bracket the measured number.
By their numbers in this assay, from the lowest: compound 3; then compounds 2 and 1 (each within the scatter of the next).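

Among the compounds shown here, this is the first change to the aryl group on the shared core that moves the number beyond the scatter in this assay, with 4-nitrophenyl in place of 2-methylphenyl giving a 2.2-fold lower number from compound 2 to compound 3 (0.34 log units; beyond the scatter) on the same core. Nitro in place of hydrogen gives a 2.3-fold lower number from compound 1 to compound 3 (0.36 log units; beyond the scatter) as a modest step, while methyl in place of hydrogen gave a 1.0-fold lower number from compound 1 to compound 2 (0.02 log units; within the scatter) within the scatter, so among these three compounds the aryl group can shift the number, though not every added group does so. What lies behind the difference between the nitro and methyl compounds remains unexplained, as no supporting measurement is available.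

The compounds shown leave open whether the lower number belongs to the nitro group itself or to its place on the ring, as 2-methylphenyl and 4-nitrophenyl differ in both the group and where it sits. They also leave open how an amine or a carboxylic acid on this aryl ring would compare, and whether any such group could move the number further than this modest step.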